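The source may report more compounds than this note shows. Statements on the series, on what has been measured and on what is new or still open speak of the compounds shown alone.

Measured so far in a functional assay on CCRF-CEM cells (Homo sapiens) for inhibition; on this read-out lower numbers stand for stronger inhibition and higher numbers for weaker inhibition:
compound 1 `CCOC(=O)CC[C@H](NC(=O)CC[C@H](NC(=O)c1ccc(N(C)Cc2cnc3nc(N)nc(N)c3n2)cc1)C(=O)OCC)C(=O)OCC` gives 1.8 ug/mL
compound 2 `CCOC(=O)CC[C@H](NC(=O)[C@H](CCC(=O)O)NC(=O)c1ccc(N(C)Cc2cnc3nc(N)nc(N)c3n2)cc1)C(=O)OCC` gives 10 ug/mL
compound 3 `CCOC(=O)CC[C@H](NC(=O)CC[C@H](NC(=O)c1ccc(N(C)Cc2cnc3nc(N)nc(N)c3n2)cc1)C(=O)N[C@@H](CCC(=O)OCC)C(=O)OCC)C(=O)OCC` gives 3.8 ug/mL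

Among these three, compound 1 has the lowest number in this assay; compound 3 lies beyond the scatter above it, and compound 2 further still. Compound 4 `CCOC(=O)CC[C@H](NC(=O)CC[C@H](NC(=O)c1ccc(N(C)Cc2cnc3nc(N)nc(N)c3n2)cc1)C(=O)O)C(=O)OCC` has not yet been measured. It differs from compound 1 in one place: hydrogen in place of ethyl on an oxygen next to a carbonyl group. For the measured compounds named here, no pair of measured compounds shows this change by itself, so the size of the step is uncertain. Going by the values given here, compound 2, the only measured compound carrying a carboxy group, gives the highest number of the three, which points toward a weaker result for compound 4. The step of a 3.3-fold higher number from compound 1 to compound 4 (0.52 log units; beyond the scatter) is expected to go toward higher numbers, beyond the scatter. Compound 4 is therefore estimated at 6 ug/mL, with a likely range from 2 ug/mL to 20 ug/mL.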

Compound 4, concentration for 50% inhibition: 0.88 ug/mL
Beside the measured number, compound 4's estimate is 6.8-fold (0.83 log units) above it; the measured number lies below the stated range.
By their numbers in this assay, from the lowest: compound 4; then compound 1; then compound 3; then compound 2.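

In this assay, for the compounds shown here, the change from ethoxycarbonyl to carboxy gives a 2.0-fold lower number from compound 1 to compound 4 (0.31 log units; beyond the scatter) and is the first single change that can be read. The ethyl on this oxygen is therefore not needed for the low number of compound 1, and a carboxy group is accepted in its place. Nothing measured here offers an explanation for this step.

Still open, as far as these compounds go, is whether a methyl ester or a longer chain such as butyl would fit this oxygen equally well. Also open, from the compounds shown here alone, is whether a primary amide could replace the carboxy group without raising the number.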